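Swapping the acyl group for a sulfonyl on the shared core

The compounds below may be only part of what the source reports. "The series", "measured", "known", "first", "only" and "open" are said of these compounds alone.

Three compounds share one core and differ only in the group on a nitrogen on an aromatic ring: compound 1 `CCC(=O)N(C)c1ccc2[nH]c(-c3n[nH]c4ccccc34)cc2n1`, compound 2 `CN(C(=O)CCc1ccccc1)c1ccc2[nH]c(-c3n[nH]c4ccccc34)cc2n1` and compound 3 `CN(C(=O)c1ccco1)c1ccc2[nH]c(-c3n[nH]c4ccccc34)cc2n1`. In a functional assay on HL-60 cells (Homo sapiens) for antiproliferative activity, read by MTT assay, with a stated time of 72 h (a higher number here means a weaker inhibitor, a lower number a stronger inhibitor), compound 1 gives 6130 nM, compound 2 gives 4730 nM and compound 3 gives 4540 nM. The step of a 1.3-fold lower number from compound 1 to compound 2 (0.11 log units; within the scatter), the step of a 1.4-fold lower number from compound 1 to compound 3 (0.13 log units; within the scatter) and the step of a 1.0-fold lower number from compound 2 to compound 3 (0.02 log units; within the scatter) are each within the scatter, so the three compounds cannot be told apart on these numbers, and compound 3 does not stand out from the other two.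

Compound 4 `CN(c1ccc2[nH]c(-c3n[nH]c4ccccc34)cc2n1)S(=O)(=O)c1ccc(Cl)cc1` is not yet measured. It differs from compound 3 in one place: (4-chlorophenyl)sulfonyl in place of (furan-2-yl)carbonyl on a nitrogen on an aromatic ring. Among the compounds with values here, no measured step covers a change of this kind, where the carbonyl itself is replaced. Within the data shown here, the measured steps show only that exchanging one acyl group for another left the number unchanged within the scatter. On that basis the step of a 1.0-fold lower number from compound 3 to compound 4 (0.00 log units; within the scatter) is expected to stay within the scatter, in no set direction. Compound 4 is therefore estimated to give 4500 nM, with a range from 1500 nM to 14000 nM.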

Compound 4, half-maximal inhibitory concentration: 770 nM
For compound 4 the middle estimate is 5.8-fold (0.77 log units) above the measured one, and the stated range ends above it.
By their numbers in this assay, from the lowest: compound 4; then compounds 3, 2 and 1 (each within the scatter of the next).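

In this assay the group on a nitrogen on an aromatic ring does matter: the three acyl groups could not be told apart, yet (4-chlorophenyl)sulfonyl gives a 5.9-fold lower number from compound 3 to compound 4 (0.77 log units; beyond the scatter), a 6.1-fold lower number from compound 2 to compound 4 (0.79 log units; beyond the scatter) and an 8.0-fold lower number from compound 1 to compound 4 (0.90 log units; beyond the scatter). All three steps lie beyond the scatter, so compound 4 is the strongest inhibitor of the four, and this position is not as indifferent to change as the acyl series suggested. No measurement is available that would explain this gain.

The change replaces the carbonyl and the ring together, so the compounds shown do not separate the part played by the sulfonyl from that of the 4-chlorophenyl ring. A 4-chlorobenzoyl group or a methylsulfonyl group on the same nitrogen would pull those two parts apart.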